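The source may report more compounds than this note shows. Statements on the series, on what has been measured and on what is new or still open speak of the compounds shown alone.

Measured in a functional assay on HEK293 cells for negative allosteric modulation of metabotropic glutamate receptor 5 (Rattus norvegicus), read by FLIPR and calcium flux, with a stated time of 170 s; a lower number here means a stronger inhibitor, a higher number a weaker inhibitor:
Compound 1, `c1ccc(COc2cc3n(n2)CCCC3)nc1`: 2500 nM
Compound 2, `N#Cc1ccc(CC(=O)c2nn3c(c2Cl)CCCC3)nc1`: 108 nM

Of these two numbers, compound 2 holds the lower one; the number of compound 1 lies beyond the scatter above it, so compound 2 stands as the stronger inhibitor of the pair. Compound 3, `N#Cc1ccc(CC(=O)c2nn3c(c2C#N)CCCC3)nc1`, is not yet measured. It differs from compound 2 in one place: cyano in place of chloro on an aromatic carbon. For the measured compounds named here, no pair of measured compounds shows what this swap does on the shared core, so nothing measured points to a direction. The change is confined to one substituent on the core, and the expectation is a step of the size that stays within the usual scatter, with no set direction. The estimate for compound 3 in this assay is 80 nM, with a range from 25 nM to 250 nM. The expected step of a 1.4-fold lower number from compound 2 to compound 3 (0.13 log units; within the scatter) is thus one that does not clearly leave the scatter.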

Compound 3, half-maximal inhibitory concentration: 5380 nM
Beside the measured number, compound 3's estimate is 67-fold (1.83 log units) below it; the measured number lies above the stated range.
By their numbers in this assay, from the lowest: compound 2; then compound 1; then compound 3.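

Within this assay, putting cyano in place of chloro on an aromatic carbon of the five-membered aromatic ring gives a 50-fold higher number from compound 2 to compound 3 (1.70 log units; beyond the scatter) and so shows that this position does not tolerate every small substituent equally. The change adds only one heavy atom and one hydrogen-bond acceptor, yet the step is large, so a single group at this place can separate a strong inhibitor from a weak one. Nothing available here explains why cyano fares so much worse than chloro.

Chloro and cyano are the only two groups shown at this position, so they give no trend across substituents. Fluoro, bromo, methyl or an amine on the same carbon would show whether chloro is unusually favourable or cyano unusually poor.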